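The source may report more compounds than this note shows. Statements on the series, on what has been measured and on what is new or still open speak of the compounds shown alone.

Measured compounds in a functional assay on HL-60 cells (Homo sapiens) for antiproliferative activity, with a stated time of 24 h; on this read-out lower numbers stand for stronger inhibition and higher numbers for weaker inhibition:
Compound 1 `NC(=O)c1c(NC(=O)c2ccccc2Cl)sc2c1CCN(C(=S)Nc1cc(C(F)(F)F)cc(C(F)(F)F)c1)C2` gives 6500 nM.
Compound 2 `NC(=O)c1c(NC(=O)c2ccccc2F)sc2c1CCN(C(=S)Nc1cc(C(F)(F)F)cc(C(F)(F)F)c1)C2` gives 17900 nM.
Compound 3 `Cc1ccccc1NC(=S)N1CCc2c(sc(NC(=O)c3ccccc3C(F)(F)F)c2C(N)=O)C1` gives 25100 nM.

Among these three numbers compound 2 stands second highest. Its nearest neighbour is compound 3, whose value lies within the usual scatter of that of compound 2, so the two cannot be ranked against each other. Going by the values given here, its only recorded step is a 2.8-fold higher number from compound 1 to compound 2 (0.44 log units; beyond the scatter), a modest weakening that goes beyond the scatter.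

Compound 4 `NC(=O)c1c(NC(=O)c2ccc(C(F)(F)F)cc2)sc2c1CCN(C(=S)Nc1cc(C(F)(F)F)cc(C(F)(F)F)c1)C2` differs from compound 2 by 4-(trifluoromethyl)phenyl in place of 2-fluorophenyl on a carbonyl carbon. Among the compounds with values here, no measured pair shows exactly this exchange. Within the data shown here, the only step that touches the same benzoyl ring is a 2.8-fold higher number from compound 1 to compound 2 (0.44 log units; beyond the scatter), and it shows that swapping one halogen for another on that ring shifts this assay by a modest amount. Among the measured compounds shown here, compound 3 carries a trifluoromethyl group on its benzoyl ring, but in a different position and with a different thiourea aryl group, so its value tells only that such a ring is compatible with a number close to that of compound 2. The expected step is therefore small and of uncertain direction, a 1.2-fold lower number from compound 2 to compound 4 (0.08 log units; within the scatter). Compound 4 is estimated at 15000 nM, with a range from 4000 nM to 50000 nM.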

Compound 4, half-maximal inhibitory concentration: 16300 nM
Estimate against measurement, compound 4: 1.1-fold (0.04 log units) below; measured number inside the range.
By their numbers in this assay, from the lowest: compound 1; then compounds 4, 2 and 3 (each within the scatter of the next).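

In this assay, 4-(trifluoromethyl)phenyl in place of 2-fluorophenyl on the carbonyl carbon gives a 1.1-fold lower number from compound 2 to compound 4 (0.04 log units; within the scatter) and so leaves the number unresolved from that of compound 2. The earlier step covered only one halogen exchanged for another, whereas this one changes the whole substituted ring and still produces no measurable shift. Set against 2-chlorophenyl, the same group gives a 2.5-fold higher number from compound 1 to compound 4 (0.40 log units; beyond the scatter) and thus a gap of the same modest kind as the earlier step, which leaves compound 1 alone at the low end of these three closely related compounds.

Going by these compounds, whether a plain phenyl, or a ring bearing an amine or a carboxylic acid, would fit this carbonyl carbon as well remains open. Nothing available here offers an explanation for these numbers.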